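The source may report more compounds than this note shows. Statements on the series, on what has been measured and on what is new or still open speak of the compounds shown alone.

In a toxicity assay on HaCaT cells (Homo sapiens) for cytotoxicity, read by CCK-8 assay, with a stated time of 24 h (a lower number here means that less compound is tolerated, a higher number that more compound is tolerated), compound 3 `COc1ccccc1Oc1c(N)nc(-c2ccc(F)cc2)nc1Cl` gives 42600 nM, the higher of the two true numbers in this small set. Compound 1 `COc1ccccc1Oc1c(N)nc(-c2ccc(C)cc2)nc1Cl` gives 6300 nM. Compound 2 `COc1ccccc1Oc1c(N)nc(-c2ccccc2F)nc1Cl` gives > 80000 nM, which is a limit of the assay and not a number.

Compound 4 `COc1ccccc1Oc1c(N)nc(-c2cccc(Br)c2)nc1Cl` departs from compound 3 by a single change, 3-bromophenyl in place of 4-fluorophenyl on an aromatic carbon. Among the compounds with values here, all the measured steps fall at this same place. The swap to fluoro gave a 6.8-fold higher number from compound 1 to compound 3 (0.83 log units; beyond the scatter), a modest step, while the other fluorinated aryl gave an at least 12-fold higher number from compound 1 to compound 2 (1.10 log units; beyond the scatter), a large one that ends on a limit. Between the two fluorinated compounds there is an at least 1.8-fold lower number from compound 2 to compound 3 (0.27 log units; that floor lies within the scatter).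

Within the data shown here, no measured step covers bromine. Among the measured compounds shown here, compound 4 carries no fluorine, and the only measured compound without it is compound 1 at 6300 nM, so a partial move towards that value is expected. The expected change is a modest one towards a lower number, a 2.8-fold lower number from compound 3 to compound 4 (0.45 log units; beyond the scatter). For compound 4 the estimate is 15000 nM, with an expected range of 4000 nM to 50000 nM.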

Compound 4, half-maximal cytotoxic concentration: 16100 nM
The estimate for compound 4 lay 1.1-fold (0.03 log units) below the measured number; low and high end bracket the measured number.
By their numbers in this assay, from the lowest: compound 1; then compound 4; then compound 3. At a limit, above all of these: compound 2.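

In this assay, a bromine-bearing aryl group at this place, on an aromatic carbon between two ring nitrogen atoms, gives a result that neither fluorinated compound nor compound 1 showed: the change to 3-bromophenyl leaves compound 4 apart from both neighbours, with a 2.6-fold higher number from compound 1 to compound 4 (0.41 log units; beyond the scatter) and a 2.6-fold lower number from compound 3 to compound 4 (0.42 log units; beyond the scatter). So an aryl group without fluorine need not sit as low as compound 1, although neither compound 2 nor compound 3 is matched. The largest step, an at least 4.9-fold lower number from compound 2 to compound 4 (0.69 log units; beyond the scatter), ends on compound 2, whose value is a limit and not a number: the limit of > 80000 nM in this assay, at which 1 of the 4 values shown sits.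

Compound 4 differs from compound 3 in both the halogen and its place on the phenyl ring, so the two effects cannot be told apart. Open too, from the compounds shown here alone, is how 4-bromophenyl, 3-fluorophenyl, or a phenyl carrying an amine or a carboxylic acid would read here.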